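Swapping a Sulfonyl Cap for a Benzyl Group

The source may report more compounds than this note shows. Statements on the series, on what has been measured and on what is new or still open speak of the compounds shown alone.

Compound 1 `CCN(CC)c1ccc2cc(C(=O)c3ccc(N4CCN(C(=O)CN5CCN(S(=O)(=O)c6ccc(C(F)(F)F)cc6)CC5)CC4)cc3)oc2c1` ends in a trifluoromethyl-bearing aromatic ring attached through a sulfonyl. In a functional assay on A549 cells (Homo sapiens) for cytotoxicity, read by MTT assay, with a stated time of 48 h (on this read-out lower numbers stand for stronger inhibition and higher numbers for weaker inhibition), compound 1 gives > 40000 nM, which is a limit of the assay rather than a number. Compound 2 `CCN(CC)c1ccc2cc(C(=O)c3ccc(N4CCN(C(=O)CN5CCN(S(=O)(=O)c6ccc(C#N)cc6)CC5)CC4)cc3)oc2c1` comes from it by a step that the two limits leave unreadable from compound 1 to compound 2. In this assay compound 2 gives > 40000 nM, again a limit and not a number. The whole picture so far is the limit of > 40000 nM in this assay, at which 2 of the 2 values shown sit, so compound 2 stands only at the edge of what the assay can report.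

Compound 3 `CCN(CC)c1ccc2cc(C(=O)c3ccc(N4CCN(C(=O)CN5CCN(Cc6ccc(C(F)(F)F)cc6)CC5)CC4)cc3)oc2c1` differs from compound 2 by 4-(trifluoromethyl)benzyl in place of (4-cyanophenyl)sulfonyl on an amine nitrogen in a ring. Among the measured compounds shown here, no measured step bears directly on this change, and the single measured step is unreadable. Compound 3 is therefore estimated at 40000 nM, within 10000 nM to 120000 nM, meaning an expected step of a number no higher from compound 2 to compound 3 (the limit leaves the size open), most likely reported again only as a limit.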

Compound 3, half-maximal inhibitory concentration: 20100 nM
For compound 3 the middle estimate is 2.0-fold (0.30 log units) above the measured one, within the range that was stated.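

At this amine nitrogen in a ring, 4-(trifluoromethyl)benzyl gives the only true number among the compounds shown in this assay: compound 3 reads 20100 nM. The two sulfonyl compounds give no such number, and the step between them cannot be read: the limit of > 40000 nM in this assay, at which 2 of the 3 values shown sit. The change is an at least 1.9-fold lower number from compound 2 to compound 3 (0.29 log units; that floor lies within the scatter), so this is only a floor, and the result cannot yet show a real gain beyond the scatter.

As far as these compounds go, the true value of compound 2 remains unknown, which leaves the full size of this step open. From the compounds shown here alone, it is also open how this position would respond to a longer chain in place of the benzyl link, or to an amine or a carboxylic acid in place of the trifluoromethyl on the benzyl ring.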